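This account rests on a few compounds, and the source may have more. Where it says the series, first, only, none or still open, it means among the compounds named here.

For the measured compounds named here, in an assay on cells for agonist activity at vitamin D3 receptor (Homo sapiens), with a stated time of 96 h (a lower number here means that less compound is needed, a higher number that more compound is needed for the effect), compound 3 `CCn1c(C(=O)Nc2cccc(C(F)(F)F)c2)ccc1C(CC)(CC)c1ccc(OCCC(O)(CC)CC)c(C)c1` gives 5900 nM, the second highest of the three numbers measured so far. Its nearest neighbour is compound 2 `C#CCCOC(=O)c1ccc(C(CC)(CC)c2ccc(OCCC(O)(CC)CC)c(C)c2)n1CC`, which gives 6030 nM; the step between them is a 1.0-fold lower number from compound 2 to compound 3 (0.01 log units; within the scatter). Far off stands compound 1 `CCn1c(C(=O)NCCN(C)C)ccc1C(CC)(CC)c1ccc(OCCC(O)(CC)CC)c(C)c1` with 82 nM, and the step to compound 3 is a 72-fold higher number from compound 1 to compound 3 (1.86 log units; beyond the scatter).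

Compound 4 `CCOC(=O)C(CC(=O)OC)NC(=O)c1ccc(C(CC)(CC)c2ccc(OCCC(O)(CC)CC)c(C)c2)n1CC` has not been measured. It differs from compound 3 in one place: a group of 11 heavy atoms (7 carbon, 4 oxygen; no ring) in place of a group of 10 heavy atoms (7 carbon, 3 fluorine; one six-membered aromatic ring of carbon only), on an amide-type nitrogen. Going by the values given here, two measured steps bear on this change. Replacing the 2-(dimethylamino)ethyl group of compound 1 by an aryl group, or its whole amide by an alkyne ester, each raised the number by a large amount, as the steps of a 72-fold higher number from compound 1 to compound 3 (1.86 log units; beyond the scatter) and a 74-fold higher number from compound 1 to compound 2 (1.87 log units; beyond the scatter) show; yet exchanging one of those two replacements for the other left the number unchanged, as a 1.0-fold lower number from compound 2 to compound 3 (0.01 log units; within the scatter) shows. The new group in compound 4 is chain-like and oxygen-rich, resembling neither the dimethylamino chain nor the aryl group. The step in this assay from compound 3 is therefore expected to be modest and uncertain in direction, a 2.4-fold lower number from compound 3 to compound 4 (0.37 log units; beyond the scatter). Compound 4 is estimated at 2500 nM, with a range from 300 nM to 15000 nM.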

Compound 4, half-maximal effective concentration: 21 nM
Beside the measured number, compound 4's estimate is 120-fold (2.08 log units) above it; measured number outside the range, below it.
By their numbers in this assay, from the lowest: compound 4; then compound 1; then compounds 3 and 2 (each within the scatter of the next).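

The amide-type nitrogen is not limited to the 2-(dimethylamino)ethyl group of compound 1 for reaching a low number in this assay: the chain with two ester groups gives a 280-fold lower number from compound 3 to compound 4 (2.45 log units; beyond the scatter) when it replaces 3-(trifluoromethyl)phenyl, and a 290-fold lower number from compound 2 to compound 4 (2.46 log units; beyond the scatter) when the whole amide stands in place of the but-3-yn-1-yl ester. It even goes past the earlier best, with a 3.9-fold lower number from compound 1 to compound 4 (0.59 log units; beyond the scatter), so among these compounds a nitrogen in this side chain is not needed for a low number. No measurement here explains why this chain does so well.

The compounds shown leave open which part of the new chain matters, and whether a single ester group on a shorter chain would give a similar number. They also leave open whether a carboxylic acid in place of either ester would keep the number low.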